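This account rests on a few compounds, and the source may have more. Where it says the series, first, only, none or still open, it means among the compounds named here.

Measured compounds:
compound 1, `C=CCCSC[C@H](N)C(=O)OC`, 45500 nM
compound 2, `C=CCCCSC[C@H](N)C(=O)OC`, 31300 nM
compound 3, `C=CCCSC[C@H](NC(=O)c1cc(O)cc(O)c1)C(=O)OC`, 35800 nM

Compounds 1 and 2 share a core; the change between them is allyl in place of vinyl on a saturated chain carbon, two bonds along the chain from a sulfur. In an assay on RAW264.7 cells for antagonist activity at Toll-like receptor 2 (Mus musculus), read by Griess assay, with a stated time of 24 h (on this read-out lower numbers stand for stronger inhibition and higher numbers for weaker inhibition), this change gave a 1.5-fold lower number from compound 1 to compound 2 (0.16 log units; within the scatter), a step that does not rise above the usual scatter. Compound 3 carries a different core; the difference between the two cores is not broken down here. In this assay compound 3 gives 35800 nM, which sits within the scatter of the numbers for compound 1 and compound 2.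

Compound 4, `C=CCCCSC[C@H](NC(=O)c1cc(O)cc(O)c1)C(=O)OC`, is not yet measured. It differs from compound 3 by allyl in place of vinyl on a saturated chain carbon, two bonds along the chain from a sulfur, and the place named there reads the same as for the change from compound 1 to compound 2, so this is the same change made on the other core. Because the measured instance gave a 1.5-fold lower number from compound 1 to compound 2 (0.16 log units; within the scatter), the expected step is of like size, a 1.4-fold lower number from compound 3 to compound 4 (0.14 log units; within the scatter), and stays within the scatter. In this assay compound 4 is expected to give 26000 nM, estimated to fall between 12000 nM and 60000 nM.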

Compound 4, half-maximal inhibitory concentration: 57800 nM
Estimate against measurement, compound 4: 2.2-fold (0.35 log units) below, and the stated range covers the measured number.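

In this assay, putting allyl in place of vinyl on a saturated chain carbon, two bonds along the chain from a sulfur, gave a 1.6-fold higher number from compound 3 to compound 4 (0.21 log units; within the scatter). Set beside the same change on the core of compound 1, neither step nor the gap between them stands clear of the scatter: the same change on two cores in this assay, a 1.5-fold lower number (0.16 log units; within the scatter) from compound 1 to compound 2 and a 1.6-fold higher number (0.21 log units; within the scatter) from compound 3 to compound 4, 2.3-fold (0.37 log units) apart, within the scatter of two such steps. This shows that the change stayed within the scatter on both cores, but it does not show that the change has a real effect on either core, nor that its direction differs from one core to the other.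

The compounds shown leave open how the number would respond to a chain longer than pent-4-en-1-yl on the sulfur, or to a saturated chain such as pentyl. They also leave open what a free carboxylic acid in place of the methyl ester would give on either core.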